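Losing the 3-methylbut-2-en-1-yl chain from compound 2

The source may report more compounds than this note shows. Statements on the series, on what has been measured and on what is new or still open speak of the compounds shown alone.

Compound 1 `COc1ccc(/C=C/C(=O)c2c(OC)cc(O)c(CC=C(C)C)c2O)cc1OC` gives 27700 nM in a functional assay on HeLa cells (Homo sapiens) for inhibition, read by MTT assay, with a stated time of 72 h; a higher number here means a weaker inhibitor, a lower number a stronger inhibitor.
Compound 2 `COc1cc(OC)c(OC)cc1/C=C/C(=O)c1c(OC)cc(O)c(CC=C(C)C)c1O` gives > 50000 nM in this assay, a limit and not a number.

Compound 2 thus stands at the limit of > 50000 nM in this assay, at which 1 of the 2 values shown sits, and has no exact value. Compound 3 `COc1cc(OC)c(OC)cc1/C=C/C(=O)c1c(O)cc(O)cc1OC` differs from it by one change: hydrogen in place of 3-methylbut-2-en-1-yl on an aromatic carbon. Within the data shown here, the only measured step, an at least 1.8-fold higher number from compound 1 to compound 2 (0.25 log units; that floor lies within the scatter), comes from a different change, methoxy in place of hydrogen on an aromatic carbon. Among the measured compounds shown here, no measured step therefore speaks to the loss of the chain, and no firm size or direction can be drawn for this assay. The lowest number available, from compound 1 at 27700 nM, still points to a weak compound, so compound 3 is expected to stay in that region. The expected change is a step that the limit leaves unreadable from compound 2 to compound 3, an estimate only. For compound 3 the estimated value is 60000 nM, with an expected range from 25000 nM to 120000 nM.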

Compound 3, half-maximal inhibitory concentration: 37800 nM
Compound 3: middle estimate off by 1.6-fold (0.20 log units), on the high side; the range from low to high includes it.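

Replacing the 3-methylbut-2-en-1-yl chain with hydrogen on the aromatic carbon ortho to two hydroxy groups now has a measured step of its own, an at least 1.3-fold lower number from compound 2 to compound 3 (0.12 log units; that floor lies within the scatter). In this assay compound 3, which has no such chain, still gives an exact number of 37800 nM, so the chain is not needed for a readable value on this scaffold. Compound 2 has only a limit and not a number, so the step is a floor and its true size stays unknown: the limit of > 50000 nM in this assay, at which 1 of the 3 values shown sits.

Going by these compounds, whether a small group such as a methyl, or an amine or a longer chain, on this aromatic carbon would shift the number in this assay stays open. Also open, on these data alone, is whether losing the chain from compound 1, with its different methoxy pattern, would give a step in the same direction.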